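The compounds below may be only part of what the source reports. "The series", "measured", "known", "first", "only" and "open" are said of these compounds alone.

Compound 1 `O=S(=O)(Nc1ccc2oc(-c3ccccc3)nc2c1)c1cccc(C(F)(F)F)c1`, compound 2 `O=S(=O)(Nc1ccc(-c2nc3ccccc3o2)cc1)c1cccc(Cl)c1` and compound 3 `O=S(=O)(Nc1ccc2oc(-c3ccccc3)nc2c1)c1cccc(Cl)c1` have been run in an assay on cells for inhibition of HSP60/HSP10 (Homo sapiens), with a stated time of 60 min; on this read-out higher numbers stand for weaker inhibition and lower numbers for stronger inhibition. Compound 1 gives only a limit there, > 100000 nM. Compound 3 likewise gives only a limit, > 100000 nM. Going by the values given here, compound 2 gives the single number in this assay, 54000 nM. The two limits together define (the limit of > 100000 nM in this assay, at which 2 of the 3 values shown sit). Compound 2 and compound 3 share the same atoms joined differently, and the difference between the two cores is not broken down here. From compound 3 to compound 1 the change is trifluoromethyl in place of chloro on an aromatic carbon, and its step is a step that the two limits leave unreadable from compound 3 to compound 1. Compound 4 `O=S(=O)(Nc1ccc(-c2nc3ccccc3o2)cc1)c1cccc(C(F)(F)F)c1` is not yet measured in this assay. From compound 2 it carries the same change, (trifluoromethyl in place of chloro on an aromatic carbon), made on the core of compound 2. The step from compound 3 to compound 1 offers no reading of this change. The step from compound 2 to compound 4 in this assay is expected to be a 1.3-fold higher number from compound 2 to compound 4 (0.11 log units; within the scatter), resting only on compound 2 at 54000 nM. For compound 4 the expected value is 70000 nM, within a range from 25000 nM to 200000 nM, with a real chance that this assay again returns only a limit.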

Compound 4, half-maximal inhibitory concentration: 57000 nM
Beside the measured number, compound 4's estimate is 1.2-fold (0.09 log units) above it; low and high end bracket the measured number.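

In this assay, trifluoromethyl in place of chloro on an aromatic carbon gives a 1.1-fold higher number from compound 2 to compound 4 (0.02 log units; within the scatter), so on the core of compound 2 this read-out does not separate the two groups. The matching step from compound 3 to compound 1 cannot be read, because both compounds give a limit and not a number: the limit of > 100000 nM in this assay, at which 2 of the 4 values shown sit. Whether the change carries from one core to another is therefore not shown, since the only readable step stands on a single core and says nothing about how the change behaves on the core of compound 1.

As far as these compounds go, it remains open whether a different kind of group on that aromatic carbon, such as an amine or a carboxylic acid, would give a step beyond the scatter on the core of compound 2. From the compounds shown here alone, it also remains open whether any group on the core of compound 1 would give a number rather than a limit, which a comparison of the same change on both cores would need.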